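A few compounds are considered here, and "the series" means these few. Any claim that something is new, unique, unknown or untested is made for them only; others in the source may bear on it.

Compound 1, `C/C(=C\CC/C(C)=C/CC[C@@H]1[C@@]2(C)CCC(=O)C(C)(C)[C@H]2CC[C@@]1(C)O)CC/C=C(\C)C(=O)OCc1cn(-c2ccccc2C)nn1`, is a triterpenoid ester carrying a 2-methylphenyl group on the triazole nitrogen. It was tested in an ADME assay on L132 cells (Homo sapiens) for cytotoxicity, read by MTT assay, with a stated time of 48 h; on this read-out lower numbers stand for stronger inhibition and higher numbers for weaker inhibition. In this assay compound 1 gives > 150000 nM, which is a limit of the assay and not a number. Compound 2, `C/C(=C\CC/C(C)=C/CC[C@@H]1[C@@]2(C)CCC(=O)C(C)(C)[C@H]2CC[C@@]1(C)O)CC/C=C(\C)C(=O)OCc1cn(C[C@@H]2O[C@H](n3ccc(=O)[nH]c3=O)[C@H]3OC(C)(C)O[C@H]32)nn1`, carries a protected nucleoside in place of the aryl group. In this assay compound 2 gives > 150000 nM, again a limit of the assay. Compound 1 therefore stands at the limit of > 150000 nM in this assay, at which 2 of the 2 values shown sit, and no order between compound 1 and compound 2 can be read from these values.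

Compound 3, `C/C(=C\CC/C(C)=C/CC[C@@H]1[C@@]2(C)CCC(=O)C(C)(C)[C@H]2CC[C@@]1(C)O)CC/C=C(\C)C(=O)OCc1cn(-c2ccc(C(C)(C)C)cc2)nn1`, has not yet been measured in this assay. It differs from compound 1 by 4-(tert-butyl)phenyl in place of 2-methylphenyl on an aromatic nitrogen. For the measured compounds named here, no step between measured compounds is available, so there is no measured precedent for this kind of change. Given that compound 1 sits at the limit, the step of a number no higher from compound 1 to compound 3 (the limit leaves the size open) is expected to be none beyond the scatter, most likely with compound 3 also reported only as a limit. Compound 3 is estimated at 150000 nM, with a range from 60000 nM to 400000 nM.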

Compound 3, half-maximal inhibitory concentration: 65800 nM
For compound 3 the middle estimate is 2.3-fold (0.36 log units) above the measured one; measured number inside the range.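

Compound 3 is the only compound shown whose result in this assay is a number and not a limit, so the group on this aromatic nitrogen proves able to shift the read-out within a shared core. On these data alone, the change to 4-(tert-butyl)phenyl gives an at least 2.2-fold lower number from compound 1 to compound 3 (0.35 log units; beyond the scatter), and the true size of that step stays open, as the starting point is a limit and not a number. Compound 1 and compound 2, with a 2-methylphenyl group and a protected nucleoside on this nitrogen, could not show this, as neither gave a number and their results sit together at the top of the measurable range: the limit of > 150000 nM in this assay, at which 2 of the 3 values shown sit.

The change alters two things at once, adding the tert-butyl group and removing the 2-methyl group, so the compounds shown cannot tell which of these accounts for the lower number. They also leave open how the read-out would respond to a plain phenyl group, a 4-methylphenyl group, or a phenyl ring bearing an amine or a carboxylic acid at this nitrogen.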